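This account rests on a few compounds, and the source may have more. Where it says the series, first, only, none or still open, it means among the compounds named here.

In a functional assay on MCF7 cells (Homo sapiens) for cytotoxicity, read by MTT assay, with a stated time of 72 h (on this read-out higher numbers stand for weaker inhibition and lower numbers for stronger inhibition), compound 3 `CC1(C)OCC(Cn2cc(Cn3c4c(c5ccccc53)C(=O)c3c[n+]([O-])c5ccccc5c3C4=O)nn2)O1` gives 290 nM. That lies within the usual scatter of compound 1 `CN(C)CCCCCn1c2c(c3ccccc31)C(=O)c1c[n+]([O-])c3ccccc3c1C2=O` at 200 nM, while compound 2 `O=C1c2c[n+]([O-])c3ccccc3c2C(=O)c2c1c1ccccc1n2CCCCn1ccnc1` at 130 nM shows a lower number, a gap beyond the scatter. Compound 4 `O=C1c2c[n+]([O-])c3ccccc3c2C(=O)c2c1c1ccccc1n2Cc1cn(CC(O)CO)nn1` differs from compound 3 in one place: 1,2-dihydroxyethyl in place of 2,2-dimethyl-1,3-dioxolan-4-yl on a saturated chain carbon bound to an aromatic nitrogen. In words, 1,2-dihydroxyethyl stands in place of 2,2-dimethyl-1,3-dioxolan-4-yl on a saturated chain carbon bound to an aromatic nitrogen. Among the measured compounds shown here, no measured step shows this change itself. The closest guide is a 1.5-fold lower number from compound 1 to compound 2 (0.19 log units; within the scatter), a different swap on a saturated chain carbon. So no shift beyond the scatter is expected, and the estimated step is a 1.1-fold lower number from compound 3 to compound 4 (0.05 log units; within the scatter). For compound 4 the estimate is 260 nM, with an expected range of 100 nM to 650 nM.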

Compound 4, half-maximal inhibitory concentration: 1110 nM
The estimate for compound 4 lay 4.3-fold (0.63 log units) below the measured number; the whole stated range lies below it.
By their numbers in this assay, from the lowest: compounds 2, 1 and 3 (each within the scatter of the next, the first and the last beyond it); then compound 4.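

In this assay, replacing 2,2-dimethyl-1,3-dioxolan-4-yl with 1,2-dihydroxyethyl gives a 3.8-fold higher number from compound 3 to compound 4 (0.58 log units; beyond the scatter), so this position does respond to the group placed there. Compound 4 also stands apart from the other two, with an 8.5-fold higher number from compound 2 to compound 4 (0.93 log units; beyond the scatter) and a 5.6-fold higher number from compound 1 to compound 4 (0.74 log units; beyond the scatter). Nothing measured here accounts for the shift.

The compounds shown do not separate the loss of the ring from the gain of hydrogen-bond donors. On these data alone, how an amine or a carboxylic acid would read in place of 1,2-dihydroxyethyl also stays open.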